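Swapping the pyrimidine on a sulfonamide thiourea

The source may hold more compounds than are shown below. What is called first, only, known or untested is meant among the compounds shown, and "the series" means these compounds.

Compound 1 `O=S(=O)(Nc1nccs1)c1ccc(N/C(S)=N\c2ccnc3cc(C(F)(F)F)ccc23)cc1`: 27200 nM
Compound 2 `O=S(=O)(Nc1ccccn1)c1ccc(N/C(S)=N\c2ccnc3cc(C(F)(F)F)ccc23)cc1`: 33500 nM
Compound 3 `Cc1cc(C)nc(NS(=O)(=O)c2ccc(N/C(S)=N\c3ccnc4cc(C(F)(F)F)ccc34)cc2)n1`: 43400 nM

In a functional assay on AS49-RAW cells (Homo sapiens) for antiproliferative activity, read by sulforhodamine B assay, with a stated time of 48 h (a lower number here means a stronger inhibitor, a higher number a weaker inhibitor), the three measured compounds sit close together: the steps of a 1.2-fold higher number from compound 1 to compound 2 (0.09 log units; within the scatter), a 1.6-fold higher number from compound 1 to compound 3 (0.20 log units; within the scatter) and a 1.3-fold higher number from compound 2 to compound 3 (0.11 log units; within the scatter) all lie within the scatter. Among the compounds with values here, compound 3 gives the highest number of the three, yet no step separates it from the others beyond the scatter, so it stands level with them.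

Compound 4 `COc1ncnc(NS(=O)(=O)c2ccc(N/C(S)=N\c3ccnc4cc(C(F)(F)F)ccc34)cc2)c1OC` differs from compound 3 only in 5,6-dimethoxypyrimidin-4-yl in place of 4,6-dimethylpyrimidin-2-yl on a sulfonamide nitrogen. Every measured step likewise exchanged the heteroaryl on the sulfonamide nitrogen, and none reached beyond the scatter. The change to compound 4 is therefore expected to give a step of a 1.1-fold lower number from compound 3 to compound 4 (0.04 log units; within the scatter), not beyond the scatter. Compound 4 is estimated at 40000 nM, with a range from 15000 nM to 100000 nM.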

Compound 4, half-maximal inhibitory concentration: 81800 nM
The estimate for compound 4 lay 2.0-fold (0.31 log units) below the measured number; low and high end bracket the measured number.
By their numbers in this assay, from the lowest: compounds 1, 2, 3 and 4 (each within the scatter of the next, the first and the last beyond it).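

Within the data shown here, on the sulfonamide nitrogen, this assay now shows steps beyond the scatter, which no earlier step reached: 5,6-dimethoxypyrimidin-4-yl gives a modest 2.4-fold higher number from compound 2 to compound 4 (0.39 log units; beyond the scatter) in place of pyridin-2-yl and a modest 3.0-fold higher number from compound 1 to compound 4 (0.48 log units; beyond the scatter) in place of 1,3-thiazol-2-yl. Against 4,6-dimethylpyrimidin-2-yl, the same group gives a 1.9-fold higher number from compound 3 to compound 4 (0.28 log units; within the scatter) and remains within the scatter, so compound 3 and compound 4 stand level. Nothing available accounts for these differences. The compounds shown leave open how a simple methyl or an unsubstituted phenyl on the sulfonamide nitrogen would compare with these heteroaryl groups.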